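The compounds below may be only part of what the source reports. "The series", "measured", "known", "first", "only" and "open" are said of these compounds alone.

In an in vitro assay on HEK385-7 cells for displacement of a labelled ligand from prostaglandin D2 receptor 2 (Homo sapiens) (on this read-out lower numbers stand for stronger inhibition and higher numbers for weaker inhibition), compound 1 `N#Cc1ccc(-c2nc(C(c3ccc(F)cc3)c3ccc(F)cc3)sc2CC(=O)O)cc1` gives 150 nM and compound 2 `O=C(O)Cc1sc(C(c2ccc(F)cc2)c2ccc(F)cc2)nc1-c1ccco1` gives 18 nM, the lower of the two numbers. Among the measured compounds shown here, the single measured step, an 8.3-fold lower number from compound 1 to compound 2 (0.92 log units; beyond the scatter), concerns the same aromatic carbon that changes here, but it swaps a six-membered for a five-membered ring. Compound 3 `O=C(O)Cc1sc(C(c2ccc(F)cc2)c2ccc(F)cc2)nc1-c1cn[nH]c1` carries 1H-pyrazol-4-yl in place of furan-2-yl on an aromatic carbon. For the measured compounds named here, no measured step exchanges one five-membered aromatic ring for another, so the estimated step is a 1.9-fold higher number from compound 2 to compound 3 (0.29 log units; within the scatter), expected to stay near the scatter. Compound 3 is therefore expected to give about 35 nM in this assay, within 9 nM to 140 nM.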

Compound 3, half-maximal inhibitory concentration: 16 nM
For compound 3 the middle estimate is 2.2-fold (0.34 log units) above the measured one, within the range that was stated.
By their numbers in this assay, from the lowest: compounds 3 and 2 (each within the scatter of the next); then compound 1.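

At this position, on an aromatic carbon next to the ring nitrogen, 1H-pyrazol-4-yl and furan-2-yl are not told apart: the step is a 1.1-fold lower number from compound 2 to compound 3 (0.05 log units; within the scatter) even though the entering ring adds a hydrogen-bond donor. The step from 4-cyanophenyl is a 9.4-fold lower number from compound 1 to compound 3 (0.97 log units; beyond the scatter) and lies beyond the scatter, so two different five-membered aromatic rings now give lower numbers than that six-membered ring. No evidence on the reason for these numbers is at hand.

On these data alone, whether the hydrogen-bond donor plays any part stays open; 1-methyl-1H-pyrazol-4-yl on this carbon would address that. Unsubstituted phenyl would separate the ring size from the nitrile.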